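Replacing a Fluorophenyl Ring with a Methoxymethyl Chain

The compounds below may be only part of what the source reports. "The series", "measured", "known", "first", "only" and "open" are said of these compounds alone.

Compound 1 `COC(=O)/C=C/c1cccc(N(Cc2ccc(/C=C/c3ccccc3F)cc2)C(=O)NC(C)C)c1`: 431 nM
Compound 2 `COC(=O)/C=C/c1cccc(N(Cc2ccc(/C=C/c3cccc(F)c3)cc2)C(=O)C2CCCCC2)c1`: 86 nM
Compound 3 `COC(=O)/C=C/c1cccc(N(Cc2ccc(-c3cc(Cl)ccc3OC)cc2)C(=O)C(C)C)c1`: 226 nM

All three were tested in an assay on isolated protein with Bile acid receptor (Homo sapiens) as the target; a lower number here means that less compound is needed, a higher number that more compound is needed for the effect. Compound 2 has the lowest number of the three; compound 3 sits above it and compound 1 further above, both beyond the scatter. Compound 4 `COC/C=C/c1ccc(CN(C(=O)C2CCCCC2)c2cccc(/C=C/C(=O)OC)c2)cc1` has not yet been measured in this assay. It differs from compound 2 in one place: methoxymethyl in place of 3-fluorophenyl on a double-bonded chain carbon bound to a double-bonded chain carbon. Going by the values given here, no pair of measured compounds differs in only one place, so no measured step guides this change. The step from compound 2 to compound 4 is expected to go toward a higher number, beyond the scatter, as a 7.0-fold higher number from compound 2 to compound 4 (0.84 log units; beyond the scatter) expresses. Compound 4 is estimated at 600 nM, with a range from 150 nM to 3000 nM.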

Compound 4, half-maximal effective concentration: 233 nM
For compound 4 the middle estimate is 2.6-fold (0.41 log units) above the measured one, within the range that was stated.
By their numbers in this assay, from the lowest: compound 2; then compounds 3, 4 and 1 (each within the scatter of the next).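

In this assay, going by these compounds alone, the change gives a 2.7-fold higher number from compound 2 to compound 4 (0.43 log units; beyond the scatter), the first direct reading of this position, and the step is a modest one. The aromatic ring is therefore not essential for a measurable value here, since the ring-free methoxymethyl chain, with fewer heavy atoms and one hydrogen-bond acceptor, still gives one. No supporting data explain the rise in the number.

Going by these compounds, whether the ring, the fluorine or the oxygen matters most remains open. Plain phenyl, a longer ether chain or an amine at this position could help separate these possibilities.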